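The compounds below may be only part of what the source reports. "The series", "measured", "known", "first", "only" and "open" are said of these compounds alone.

The three measured compounds share one core, with a small ring attached on a saturated chain carbon bound to an aromatic carbon. Compound 1 `Cc1noc(Cc2ccc3[nH]cc([C@H]4C[C@H](N(C)C)C4)c3c2)n1` gives 933 nM in an assay on CHO-K1 cells for binding affinity to 5-hydroxytryptamine receptor 1D (Homo sapiens); on this read-out lower numbers stand for stronger inhibition and higher numbers for weaker inhibition. Compound 2 `Cc1nc(Cc2ccc3[nH]cc([C@H]4C[C@H](N(C)C)C4)c3c2)n[nH]1` gives 2040 nM in this assay, the second highest of the three numbers, while compound 3 `CN(C)[C@H]1C[C@H](c2c[nH]c3ccc(CN4C(=O)NC(C)(C)C4=O)cc32)C1` gives 3090 nM. Within the data shown here, the values of compound 2 and compound 3 lie within the scatter of each other; the only step that changes a single place, a 2.2-fold higher number from compound 1 to compound 2 (0.34 log units; beyond the scatter), is a modest one. Compound 4 `CN(C)[C@H]1C[C@H](c2c[nH]c3ccc(CN4C(=O)CNC4=O)cc32)C1` differs from compound 2 by 2,5-dioxoimidazolidin-1-yl in place of 5-methyl-1H-1,2,4-triazol-3-yl on a saturated chain carbon bound to an aromatic carbon. Among the measured compounds shown here, no measured step covers this exchange. The closest guide is compound 3, whose ring is the same kind but carries additional methyl groups, and its number sits close to that of compound 2. The expected step is therefore small, a 1.2-fold higher number from compound 2 to compound 4 (0.09 log units; within the scatter), with no clear direction. Compound 4 is estimated at 2500 nM, within a range from 1100 nM to 5500 nM.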

Compound 4, half-maximal inhibitory concentration: 2450 nM
Compound 4: middle estimate off by 1.0-fold (0.01 log units), on the high side, and the stated range covers the measured number.
By their numbers in this assay, from the lowest: compound 1; then compounds 2, 4 and 3 (each within the scatter of the next).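

In this assay, the step of a 1.2-fold higher number from compound 2 to compound 4 (0.08 log units; within the scatter) shows that, on this saturated chain carbon bound to an aromatic carbon, a non-aromatic ring with two carbonyl groups cannot be told apart from an aromatic ring with three nitrogens. The ring need not be aromatic to give a number in this range, at least for these two groups. The step of a 2.6-fold higher number from compound 1 to compound 4 (0.42 log units; beyond the scatter) is modest but beyond the scatter, so compound 1 with its 3-methyl-1,2,4-oxadiazol-5-yl stays apart from compound 4, and nothing measured for these groups accounts for that gap.

From the compounds shown here alone, it remains open whether this place needs a ring at all, as an open chain such as an acetamide or a carboxylic acid could answer. A primary amine or a longer chain carrying the ring could also behave differently.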